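The source may report more compounds than this note shows. Statements on the series, on what has been measured and on what is new or still open speak of the compounds shown alone.

Three compounds sharing one core have been run in a functional assay on A549 cells (Homo sapiens) for inhibition, read by MTT assay, with a stated time of 72 h; a higher number here means a weaker inhibitor, a lower number a stronger inhibitor. Compound 1 `CN(c1ccc(Oc2ncnc3sccc23)cc1)c1nccc(N2CCc3ccccc3C2)n1` gives 6390 nM, compound 2 `CN(c1ccc(Oc2ncnc3sccc23)cc1)c1nccc(N2CCCCC2)n1` gives 8790 nM, and the step of a 1.4-fold higher number from compound 1 to compound 2 (0.14 log units; within the scatter) is small. Compound 3 `c1cc(N2CCCC2)nc(Nc2ccc(Oc3ncnc4sccc34)cc2)n1` gives 8100 nM; this number is the second highest of the three, and it lies within the scatter of both compound 1 and compound 2. The next compound, compound 4 `CN(c1ccc(Oc2ncnc3sccc23)cc1)c1nccc(N2CCCC2)n1`, differs from compound 3 by methyl in place of hydrogen on a nitrogen on an aromatic ring. Within the data shown here, no measured step matches this change on its own: compound 1 and compound 2 carry the methyl and compound 3 the hydrogen, yet each such pair also differs elsewhere, and all three numbers sit within the scatter of one another. One therefore expects no step beyond the scatter, a 1.0-fold lower number from compound 3 to compound 4 (0.01 log units; within the scatter). Compound 4 is estimated at 8000 nM, between 4000 nM and 16000 nM.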

Compound 4, half-maximal inhibitory concentration: 15100 nM
Compound 4: the middle estimate sits 1.9-fold (0.28 log units) below what was measured, and the stated range covers the measured number.
By their numbers in this assay, from the lowest: compounds 1, 3, 2 and 4 (each within the scatter of the next, the first and the last beyond it).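

The change of methyl in place of hydrogen on a nitrogen on an aromatic ring can now be read on its own as a 1.9-fold higher number from compound 3 to compound 4 (0.27 log units; within the scatter) and so stays inside the usual scatter. On the aromatic carbon, pyrrolidin-1-yl in place of piperidin-1-yl gives a 1.7-fold higher number from compound 2 to compound 4 (0.23 log units; within the scatter) and also stays inside it. Pyrrolidin-1-yl in place of 1,2,3,4-tetrahydroisoquinolin-2-yl gives a 2.4-fold higher number from compound 1 to compound 4 (0.37 log units; beyond the scatter) and is the only one of these steps to clear the scatter, and only modestly. The compounds shown leave open what an ethyl group or a longer chain on that nitrogen would do, and what morpholin-4-yl on the aromatic carbon would do. Nothing available here explains these steps.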